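Changing the Amide Group of Compound 1

This account rests on a few compounds, and the source may have more. Where it says the series, first, only, none or still open, it means among the compounds named here.

Measured compounds:
compound 1 `CCN(Cc1ccccc1)C(=O)c1nn(-c2ccc(F)cc2)c(OC[C@@H](O)C[C@@H](O)CC(=O)O)c1C(C)C`: 14 nM
compound 2 `COc1ccccc1CNC(=O)c1nn(-c2ccc(F)cc2)c(OC[C@@H](O)C[C@@H](O)CC(=O)O)c1C(C)C`: 22 nM
compound 3 `CC(C)c1c(C(=O)NCc2ccccc2Cl)nn(-c2ccc(F)cc2)c1OC[C@@H](O)C[C@@H](O)CC(=O)O`: 9.5 nM

These three compounds share one core and differ only in the amine part of the amide. In an assay on microsomes from liver for inhibition of 3-hydroxy-3-methylglutaryl-coenzyme A reductase (Rattus norvegicus) (on this read-out lower numbers stand for stronger inhibition and higher numbers for weaker inhibition), compound 1 gives 14 nM, the second highest of the three numbers; the nearest measured steps are a 1.5-fold lower number from compound 1 to compound 3 (0.17 log units; within the scatter) and a 1.6-fold higher number from compound 1 to compound 2 (0.20 log units; within the scatter), both within the scatter. Between the other two, a 2.3-fold lower number from compound 2 to compound 3 (0.36 log units; beyond the scatter).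

Compound 4 `COc1cccc(CN(C)C(=O)c2nn(-c3ccc(F)cc3)c(OC[C@@H](O)C[C@@H](O)CC(=O)O)c2C(C)C)c1` differs from compound 1 as follows: (3-methoxybenzyl)(methyl)amino in place of benzyl(ethyl)amino on a carbonyl carbon. The two measured steps that alter this same amide group stayed within the scatter, so for compound 4 a step of about a 1.1-fold higher number from compound 1 to compound 4 (0.06 log units; within the scatter) is expected, which is no change beyond the scatter. Compound 4 is therefore estimated at 16 nM, within a range from 7 nM to 40 nM.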

Compound 4, half-maximal inhibitory concentration: 21 nM
For compound 4 the middle estimate is 1.3-fold (0.12 log units) below the measured one; low and high end bracket the measured number.
By their numbers in this assay, from the lowest: compounds 3, 1, 4 and 2 (each within the scatter of the next, the first and the last beyond it).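

In this assay the amide position takes (3-methoxybenzyl)(methyl)amino, with its one hydrogen-bond acceptor, and shows a 1.5-fold higher number from compound 1 to compound 4 (0.18 log units; within the scatter) and a 1.0-fold lower number from compound 2 to compound 4 (0.02 log units; within the scatter) with no shift beyond the scatter. For the compounds shown here, only the comparison with the chloro compound separates, with a 2.2-fold higher number from compound 3 to compound 4 (0.34 log units; beyond the scatter) as the one step of compound 4 beyond the scatter. The compounds shown leave open how this amide position would respond to an amine or a carboxylic acid on the benzyl ring. No measurement at hand explains these numbers.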